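A few compounds are considered here, and "the series" means these few. Any claim that something is new, unique, unknown or untested is made for them only; others in the source may bear on it.

In a functional assay on cells (Homo sapiens) for antiproliferative activity, read by MTT assay, with a stated time of 48 h (a lower number here means a stronger inhibitor, a higher number a weaker inhibitor), compound 1 `CCn1c(N)c(-c2nc3ccccc3[nH]2)c2nc(C#N)c(C#N)nc21` gives > 50000 nM, which is a limit of the assay and not a number. Compound 2 `CCN(CC)CCn1c(N)c(-c2nc3ccccc3[nH]2)c2nc(C#N)c(C#N)nc21` gives 25400 nM. Compound 3 `N#Cc1nc2c(-c3nc4ccccc4[nH]3)c(N)n(CCN3CCCC3)c2nc1C#N` gives > 50000 nM, again only a limit. It therefore stands with the limit of > 50000 nM in this assay, at which 2 of the 3 values shown sit.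

Compound 4 `CN1CCN(CCn2c(N)c(-c3nc4ccccc4[nH]3)c3nc(C#N)c(C#N)nc32)CC1` has not yet been measured. It departs from compound 3 by one change: 4-methylpiperazin-1-yl in place of pyrrolidin-1-yl on a saturated chain carbon, two bonds along the chain from an aromatic nitrogen. The 4-methylpiperazin-1-yl group takes the place of pyrrolidin-1-yl on a saturated chain carbon, two bonds along the chain from an aromatic nitrogen.

Within the data shown here, three measured steps touch that same place. The first is an at least 1.9-fold lower number from compound 1 to compound 2 (0.29 log units; that floor lies within the scatter), and the second is an at least 1.9-fold higher number from compound 2 to compound 3 (0.29 log units; that floor lies within the scatter). The third is a step that the two limits leave unreadable from compound 1 to compound 3. Compound 2, at 25400 nM, is the only one of the three to give a number, so no step beyond the scatter is expected for the new group in this assay. A further limit would be no surprise.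

The step expected is an at least 1.2-fold lower number from compound 3 to compound 4 (0.09 log units; that floor lies within the scatter). For compound 4 the estimated value is 40000 nM, with an expected range from 18000 nM to 70000 nM.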

Compound 4, half-maximal inhibitory concentration: 9110 nM
Beside the measured number, compound 4's estimate is 4.4-fold (0.64 log units) above it; the whole stated range lies above it.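

In this assay, among these compounds, 4-methylpiperazin-1-yl gives the first step at this saturated chain carbon, two bonds along the chain from an aromatic nitrogen, that is printed as beyond the scatter: an at least 5.4-fold lower number from compound 3 to compound 4 (0.73 log units; beyond the scatter), and likewise an at least 5.4-fold lower number from compound 1 to compound 4 (0.73 log units; beyond the scatter). Among the compounds shown here, it also stands clear of the only earlier compound with a number, with a 2.8-fold lower number from compound 2 to compound 4 (0.45 log units; beyond the scatter), so compound 4 is the most potent of the four and the choice of group at this place does register in the read-out. The steps from compound 1 and compound 3 are floors only, since each of these two compounds stands at a limit of the assay: the limit of > 50000 nM in this assay, at which 2 of the 4 values shown sit.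

The compounds shown do not separate the second ring nitrogen from the methyl on it, which piperazin-1-yl or morpholin-4-yl at the same place would address. They also leave open whether a longer chain, such as 3-(4-methylpiperazin-1-yl)propyl, keeps this step.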